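The source may hold more compounds than are shown below. What is called first, only, known or untested is meant among the compounds shown, and "the series" means these compounds.

Measured so far, in a functional assay for inhibition of nuclear factor NF-kappa-B complex (Homo sapiens); on this read-out higher numbers stand for weaker inhibition and lower numbers for stronger inhibition:
Compound 1 `CCOC(=O)C1=Cc2ccc(OC)cc2OC1c1cc(OC)c(OC)c(OC)c1` gives 25000 nM.
Compound 2 `COc1ccc2c(c1)OC(c1cc(OC)c(OC)c(OC)c1)C(C(=O)O)=C2` gives only a limit of the assay, > 50000 nM.
Compound 3 `COc1ccc2c(c1)OC(c1cc(OC)c(OC)c(OC)c1)C(C#N)=C2` gives 3400 nM.

Compound 3 holds the lowest of the two actual numbers, and the nearest of them lies one step away: a 7.4-fold lower number from compound 1 to compound 3 (0.87 log units; beyond the scatter). Compound 4 `CNC(=O)C1=Cc2ccc(OC)cc2OC1c1cc(OC)c(OC)c(OC)c1` is the compound still to be measured. Compared with compound 3 it differs in one place: methylcarbamoyl in place of cyano on a double-bonded ring carbon.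

Among the compounds with values here, two measured steps bear on this change, both moving from a carbonyl-bearing group to cyano on the same ring carbon: a 7.4-fold lower number from compound 1 to compound 3 (0.87 log units; beyond the scatter) and an at least 14-fold lower number from compound 2 to compound 3 (1.16 log units; beyond the scatter). The change to compound 4 runs the other way, from cyano back to a carbonyl-bearing group, methylcarbamoyl. A higher number is therefore expected, roughly of the size seen for the ester, with the carboxy case showing that the rise could be larger. Compound 4 is estimated to give 15000 nM in this assay, within a range from 4000 nM to 50000 nM. That estimate amounts to a 4.4-fold higher number from compound 3 to compound 4 (0.64 log units; beyond the scatter).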

Compound 4, half-maximal inhibitory concentration: > 50000 nM
Compound 4 gave a limit, no number; the forecaster's own chance of this, stated with the estimate: 20%; middle value at least 3.3-fold (0.52 log units) from the limit.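

The amide behaves like the other carbonyl-bearing groups at this double-bonded ring carbon in this assay, and it costs at least as much as they do: an at least 14-fold higher number from compound 3 to compound 4 (1.16 log units; beyond the scatter). Among the compounds shown, all three carbonyl-bearing groups give weaker inhibition than cyano, and none goes against this pattern. The ester and the amide cannot be ranked, since the floor of their step lies within the scatter: an at least 2.0-fold higher number from compound 1 to compound 4 (0.30 log units; that floor lies within the scatter).

On these data alone, the value of compound 4 is a limit of the assay and not a number, and the step between compound 2 and compound 4 cannot be read: the limit of > 50000 nM in this assay, at which 2 of the 4 values shown sit. Still open is how an unsubstituted carbamoyl group, a longer chain on the amide nitrogen or an amine would behave on this ring carbon.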